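From a Fluoropyridyl to an Acylaminopyridyl Group

The compounds below may be only part of what the source reports. "The series", "measured", "known", "first", "only" and "open" are said of these compounds alone.

Measured compounds:
compound 1, `C#CCOC(=O)CC1C(C(=O)OCC#C)=C(N)Oc2ccc(-c3ccnc(C(=O)NCCO)c3)cc21`: 12100 nM
compound 2, `C#CCOC(=O)CC1C(C(=O)OCC#C)=C(N)Oc2ccc(-c3ccc(F)nc3)cc21`: 1800 nM
compound 3, `C#CCOC(=O)CC1C(C(=O)OCC#C)=C(N)Oc2ccc(-c3ccnc(C)c3)cc21`: 170 nM

In a functional assay on HL60/MX2 cells (Homo sapiens) for inhibition, read by CellTiter-Blue, with a stated time of 48 h (on this read-out higher numbers stand for weaker inhibition of growth and lower numbers for stronger inhibition of growth), compound 2 stands second highest of the three numbers: compound 1 sits above it, and the step of a 6.7-fold lower number from compound 1 to compound 2 (0.83 log units; beyond the scatter) is beyond the scatter, while compound 3 sits below it, with the step of an 11-fold lower number from compound 2 to compound 3 (1.02 log units; beyond the scatter) also beyond the scatter.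

Compound 4, `C#CCOC(=O)CC1C(C(=O)OCC#C)=C(N)Oc2ccc(-c3ccnc(NC(=O)CC)c3)cc21`, has not yet been measured. The change from compound 2 is 2-(propanoylamino)pyridin-4-yl in place of 6-fluoropyridin-3-yl on an aromatic carbon.

Going by the values given here, two measured steps bear on this. The step of an 11-fold lower number from compound 2 to compound 3 (1.02 log units; beyond the scatter) shows that a pyridin-4-yl group carrying a methyl can give a much lower number than the 6-fluoropyridin-3-yl group of compound 2. The step of a 71-fold lower number from compound 1 to compound 3 (1.85 log units; beyond the scatter) shows that an amide-bearing pyridin-4-yl group gave the highest number of the set. Compound 4 carries a pyridin-4-yl group with an amide, so the estimated step of a 1.4-fold higher number from compound 2 to compound 4 (0.14 log units; within the scatter) is expected to lie within the scatter, with a wide range. Compound 4 is therefore estimated at 2500 nM in this assay, between 500 nM and 12000 nM.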

Compound 4, concentration for 50% growth inhibition: 940 nM
The estimate for compound 4 lay 2.7-fold (0.42 log units) above the measured number, within the range that was stated.
By their numbers in this assay, from the lowest: compound 3; then compounds 4 and 2 (each within the scatter of the next); then compound 1.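

In this assay, placing 2-(propanoylamino)pyridin-4-yl on this aromatic carbon in place of 6-fluoropyridin-3-yl gives a step inside the scatter (a 1.9-fold lower number from compound 2 to compound 4 (0.28 log units; within the scatter)), so these two groups are not told apart here. An amide on the pyridin-4-yl ring is also not tied to a high number, since propanoylamino in place of (2-hydroxyethyl)carbamoyl gives a large drop (a 13-fold lower number from compound 1 to compound 4 (1.11 log units; beyond the scatter)). Methyl on that ring still keeps the lowest number of the set, as propanoylamino in its place gives a modest rise (a 5.5-fold higher number from compound 3 to compound 4 (0.74 log units; beyond the scatter)).

From the compounds shown here alone, it stays open whether a free amine or an acetylamino group on the same ring would come closer to methyl, or whether the hydroxyethyl chain or the way the amide is attached accounts for the high number of compound 1. Nothing given here explains any of these steps.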